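The source may hold more compounds than are shown below. What is called first, only, known or untested is meant among the compounds shown, and "the series" means these compounds.

Measured so far in a functional assay on brain (Rattus norvegicus, strain Wistar) for inhibition; a higher number here means a weaker inhibitor, a lower number a stronger inhibitor:
- Compound 1 `Cc1[nH]c(=O)n(C)c1-c1ccccc1`: > 100000 nM, a limit of the assay and not a number
- Compound 2 `Cc1ccc(-c2c(C)[nH]c(=O)n2C)cc1`: 85300 nM

Among the compounds with values here, compound 2 carries the only true number so far, 85300 nM. Compound 1 gives only a limit of the assay.

The next compound, compound 3 `COc1ccc(-c2c(C)[nH]c(=O)n2C)cc1`, has methoxy in place of methyl on an aromatic carbon of a six-membered aromatic ring of carbon only: methoxy in place of methyl on an aromatic carbon. Within the data shown here, the one measured step that bears on this change is the one that introduced a methyl on an aromatic carbon, an at least 1.1-fold lower number from compound 1 to compound 2 (0.06 log units; that floor lies within the scatter). It is known only as a floor within the scatter, so it sets no firm size or direction for a further change. The expected step, a 1.2-fold lower number from compound 2 to compound 3 (0.09 log units; within the scatter), is therefore none beyond the scatter. For compound 3 the estimated value is 70000 nM, with an expected range from 25000 nM to 150000 nM.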

Compound 3, half-maximal inhibitory concentration: 147000 nM
Beside the measured number, compound 3's estimate is 2.1-fold (0.32 log units) below it; low and high end bracket the measured number.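

In this assay, putting methoxy in place of methyl at this carbon of the six-membered ring gives a 1.7-fold higher number from compound 2 to compound 3 (0.24 log units; within the scatter). Within the data shown here, this is the first step here between two true numbers, and it shows that compounds 2 and 3 cannot be told apart, even though the change adds a heavy atom and a hydrogen-bond acceptor. The step between compound 1 and compound 3 cannot be read, because compound 1 stands at a limit of the assay and not at a number: the limit of > 100000 nM in this assay, at which 1 of the 3 values shown sits.

From the compounds shown here alone, whether an amine, a carboxylic acid or a longer chain such as butyl at this carbon would shift the number beyond the scatter remains open. So does whether methyl and methoxy would also match at other carbons of this ring.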